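Bromo in Place of Hydrogen: What Compound 3 Is Expected to Show

The compounds below may be only part of what the source reports. "The series", "measured", "known", "first", "only" and "open" are said of these compounds alone.

Compound 1 `O=C1C2ON=C(c3cn(-c4ccccc4)nc3-c3ccccc3)C2C(=O)N1c1ccccc1`: 47.4%
Compound 2 `CN1C(=O)C2ON=C(c3cn(-c4ccccc4)nc3-c3ccccc3)C2C1=O`: 30.6%

Going by the values given here, in a functional assay on the whole organism (Abdomen, strain Swiss albino) with Mus musculus as the target, with stated times of 10 min and 5 min, at a dose of 30 mg/kg by the oral route (a higher number here means a stronger effect of the compound at the dose given, a lower number a weaker effect), compound 1 gives 47.4%, the higher of the two numbers measured so far, and the gap to compound 2 is beyond the scatter. Compound 2 gives 30.6%. Among the compounds with values here, the only measured step, a number 16.8 percentage points lower from compound 1 to compound 2 (beyond the scatter), comes from a methyl in place of phenyl on an amide-type nitrogen in a ring.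

Compound 3 `O=C1C2ON=C(c3cn(-c4ccccc4)nc3-c3ccc(Br)cc3)C2C(=O)N1c1ccccc1` differs from compound 1 by bromo in place of hydrogen on an aromatic carbon. Within the data shown here, no measured step concerns this part of the molecule; the one step known alters the amide-type nitrogen instead and offers no guide for a bromo entering the phenyl ring. With nothing in the data pointing either way, the change is expected to fall within the scatter, giving a number 0.4 percentage points lower from compound 1 to compound 3 (within the scatter). Compound 3 is therefore estimated to give 47%, with a range from 30% to 64%.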

Compound 3, a percentage reported as activity, at one dose (the size of the read-out at that dose, not a potency): 49%
The estimate for compound 3 lay 2 percentage points below the measured number, and the stated range covers the measured number.
By their numbers in this assay, from the lowest: compound 2; then compounds 1 and 3 (each within the scatter of the next).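

In this assay, going by these compounds alone, the change from phenyl to 4-bromophenyl comes with a number 1.6 percentage points higher from compound 1 to compound 3 (within the scatter), the first measured step on this part of the molecule. Thus a bromo on an aromatic carbon, para to a large group, leaves the read-out of compound 1 within the scatter, whereas the change on the amide-type nitrogen gave a number 16.8 percentage points lower from compound 1 to compound 2 (beyond the scatter). Nothing available explains why this position shows so little response to bromo.

Whether an amine, a carboxylic acid or a methoxy group at this same position would also stay within the scatter remains open, since bromo is the only replacement for hydrogen shown here. From the compounds shown here alone, it is also open whether the same bromo would leave the read-out of compound 2 within the scatter, with methyl on the amide-type nitrogen.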